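Adding a halogenated benzylsulfanyl group to a shared core

A few compounds are considered here, and "the series" means these few. Any claim that something is new, unique, unknown or untested is made for them only; others in the source may bear on it.

Of the compounds shown here, three built on one shared core have been tested in a functional assay on MGC-803 cells (Homo sapiens) for inhibition, read by MTT assay, with a stated time of 72 h; a lower number here means a stronger inhibitor, a higher number a weaker inhibitor. Compound 1 `Cc1cc(N2CC[C@@H](C)[C@@H](N(C)c3ncnc4[nH]ccc34)C2)n2ncnc2n1` carries only a hydrogen at the position of interest, and in this assay compound 1 gives 4350 nM, the lowest of the three numbers. Compound 2 `Cc1cc(N2CC[C@@H](C)[C@@H](N(C)c3ncnc4[nH]ccc34)C2)n2nc(SCc3nc4ccccc4[nH]3)nc2n1` gives 21200 nM, and compound 3 `Cc1cc(N2CC[C@@H](C)[C@@H](N(C)c3ncnc4[nH]ccc34)C2)n2nc(SCCc3ccccc3)nc2n1` gives 6190 nM. Exchanging the hydrogen for the benzimidazole-bearing thioether produced a 4.9-fold higher number from compound 1 to compound 2 (0.69 log units; beyond the scatter), whereas the phenethylsulfanyl group produced a 1.4-fold higher number from compound 1 to compound 3 (0.15 log units; within the scatter). Comparing the two substituted compounds directly, the step is a 3.4-fold lower number from compound 2 to compound 3 (0.53 log units; beyond the scatter).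

Compound 4 `Cc1cc(N2CC[C@@H](C)[C@@H](N(C)c3ncnc4[nH]ccc34)C2)n2nc(SCc3ccc(F)c(Cl)c3)nc2n1` has not yet been measured. Relative to compound 1, the change is (3-chloro-4-fluorobenzyl)sulfanyl in place of hydrogen on an aromatic carbon. Both substitutions already made at this same position, in compound 2 and in compound 3, left the number either unchanged within the scatter or modestly higher, and neither lowered it. Going by the values given here, the new group, a substituted benzene ring carried on a chain to sulfur, resembles the group in compound 3 more than the one in compound 2. The expected step for compound 4 is therefore a 1.6-fold higher number from compound 1 to compound 4 (0.21 log units; within the scatter), a small to modest rise in the number. Compound 4 is estimated at 7000 nM, within a range from 3000 nM to 18000 nM.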

Compound 4, half-maximal inhibitory concentration: 52000 nM
Compound 4: the middle estimate sits 7.4-fold (0.87 log units) below what was measured, and the stated range ends below it.
By their numbers in this assay, from the lowest: compounds 1 and 3 (each within the scatter of the next); then compound 2; then compound 4.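

In this assay the (3-chloro-4-fluorobenzyl)sulfanyl group gives a 12-fold higher number from compound 1 to compound 4 (1.08 log units; beyond the scatter) and is the largest step seen at this position, so a substituent here can cost far more than compound 3 suggested. A benzene ring carried on a sulfur-bound chain does not by itself keep the number close to that of compound 1, since the step of an 8.4-fold higher number from compound 3 to compound 4 (0.92 log units; beyond the scatter) separates two compounds that both have such a ring. The benzimidazole group also no longer marks the high end of the series, given the step of a 2.5-fold higher number from compound 2 to compound 4 (0.39 log units; beyond the scatter) to the halogenated compound.

On these data alone, compounds 3 and 4 differ in chain length and in the chlorine and fluorine together, so a plain benzylsulfanyl group would be needed to tell these two changes apart, and whether a small amine or a carboxylic acid on the sulfur chain could bring the number below that of compound 1 remains open. Nothing available here explains why this group raises the number so sharply.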